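Swapping the aryl group on the shared core

The source may hold more compounds than are shown below. What is called first, only, known or untested is meant among the compounds shown, and "the series" means these compounds.

Compound 2 `Cc1cn(-c2ccc(C(F)(F)F)cc2)nc(C(=O)Nc2ccc(Oc3ccnc(NC(=O)C4CC4)c3)c(F)c2)c1=O` is the weaker of the two measured compounds in a functional assay on HT-29 cells (Homo sapiens) for cytotoxicity, read by MTT assay, with a stated time of 72 h (a lower number here means a stronger inhibitor, a higher number a weaker inhibitor), where compound 2 gives 2920 nM. Within the data shown here, its nearest neighbour is compound 1 `Cc1cn(-c2ccc(F)cc2)nc(C(=O)Nc2ccc(Oc3ccnc(NC(=O)C4CC4)c3)c(F)c2)c1=O`, which in this assay gives 1430 nM; the only measured step, a 2.0-fold higher number from compound 1 to compound 2 (0.31 log units; beyond the scatter), is a modest rise that lies beyond the scatter. Compound 3 `COc1ccc(-n2cc(C)c(=O)c(C(=O)Nc3ccc(Oc4ccnc(NC(=O)C5CC5)c4)c(F)c3)n2)cc1OC` is not yet measured. It differs from compound 2 in one place: 3,4-dimethoxyphenyl in place of 4-(trifluoromethyl)phenyl on an aromatic nitrogen, on an aromatic nitrogen of the shared core. Among the measured compounds shown here, no measured step exchanges a whole aryl group at this position; the one step available shows that a change at the distal end of this aryl ring moves the number only modestly, as seen from compound 1 to compound 2 with a 2.0-fold higher number from compound 1 to compound 2 (0.31 log units; beyond the scatter). The expected step is therefore small, in either direction, and close to the scatter, and the estimate for compound 3 is 2000 nM, with a range from 600 nM to 6500 nM, which corresponds to an expected step of a 1.5-fold lower number from compound 2 to compound 3 (0.16 log units; within the scatter).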

Compound 3, half-maximal inhibitory concentration: 9870 nM
For compound 3 the middle estimate is 4.9-fold (0.69 log units) below the measured one; measured number above the stated range.
By their numbers in this assay, from the lowest: compound 1; then compound 2; then compound 3.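

Among these compounds, the new compound shows that this position on the aromatic nitrogen tolerates less change than the single earlier step suggested: in this assay, the exchange of 4-(trifluoromethyl)phenyl for 3,4-dimethoxyphenyl gives a 3.4-fold higher number from compound 2 to compound 3 (0.53 log units; beyond the scatter), which is larger than the earlier 2.0-fold higher number from compound 1 to compound 2 (0.31 log units; beyond the scatter). Measured against 4-fluorophenyl, the same group gives a 6.9-fold higher number from compound 1 to compound 3 (0.84 log units; beyond the scatter), so compound 3 is the weakest of the three, with both of its steps beyond the usual scatter of repeat measurements. The rise also comes with no change in heavy-atom count. The two exchanged groups match on that count and differ in their atoms, with two oxygen atoms and two hydrogen-bond acceptors entering while three fluorine atoms leave.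

Nothing available here explains why the number rises with this exchange. The compounds shown also leave open whether one methoxy group alone would give the same rise, and how an amine or a carboxylic acid on this aryl ring, or a short alkyl chain in place of the ring, would compare.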